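A few compounds are considered here, and "the series" means these few. Any claim that something is new, unique, unknown or untested is made for them only; others in the source may bear on it.

Compound 1 (`COc1cc(-c2nc(-c3ccccc3)[nH]c2-c2ccnc(NCCCNS(=O)(=O)c3ccc(Br)cc3)n2)ccc1Cl`): 23700 nM
Compound 2 (`COc1cc(-c2nc(-c3ccccc3)[nH]c2-c2ccnc(NCCCNS(=O)(=O)c3ccc(C)cc3)n2)ccc1Cl`): 18600 nM

Both numbers come from a functional assay on LOX IMVI cells (Homo sapiens) for cytotoxicity, read by MTT assay, with a stated time of 24 h (on this read-out higher numbers stand for weaker inhibition and lower numbers for stronger inhibition), and lie within the usual scatter of each other, so compound 2 stands level with compound 1. Compound 3 (`COc1cc(-c2nc(-c3ccccc3)[nH]c2-c2ccnc(NCCCNS(=O)(=O)c3cccc4ccccc34)n2)ccc1Cl`) keeps the shared core and the chain but carries naphthalen-1-yl in place of 4-methylphenyl on a sulfonyl sulfur. Going by the values given here, the one measured step is a 1.3-fold lower number from compound 1 to compound 2 (0.11 log units; within the scatter) and it exchanged only a single group on an aromatic carbon, whereas compound 3 replaces the whole aromatic group. Among the compounds with values here, that step is therefore a loose guide, and no measured step shows what a second ring does. No change beyond the scatter is expected in this assay and no direction is favoured, so the estimated move is a 1.1-fold lower number from compound 2 to compound 3 (0.04 log units; within the scatter) and no more. For compound 3 the estimate is 17000 nM with 7500 nM to 38000 nM as the expected range.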

Compound 3, half-maximal inhibitory concentration: 13500 nM
Estimate against measurement, compound 3: 1.3-fold (0.10 log units) above; low and high end bracket the measured number.
By their numbers in this assay, from the lowest: compounds 3, 2 and 1 (each within the scatter of the next).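

Exchanging the single ring on the sulfonyl sulfur for naphthalen-1-yl, which brings a second six-membered aromatic ring, gives a 1.4-fold lower number from compound 2 to compound 3 (0.14 log units; within the scatter) in this assay. Measured against 4-bromophenyl, the same group gives a 1.8-fold lower number from compound 1 to compound 3 (0.24 log units; within the scatter). The earlier pair differed only in one group on an aromatic carbon, whereas these steps show that the whole aromatic group at this position can be enlarged with no change beyond the scatter, and no available measurement explains this result.

On these data alone, all three compounds carry an aromatic group made of carbon only on the sulfonyl sulfur, so it remains open whether a pyridine ring or a simple methyl group there would shift the number beyond the scatter. As far as these compounds go, the effect of a carboxylic acid or an amine on that ring, or of a longer chain to the sulfonamide nitrogen, also remains open.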